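This account rests on a few compounds, and the source may have more. Where it says the series, first, only, none or still open, it means among the compounds named here.

In a functional assay on the whole organism with Rattus norvegicus as the target (on this read-out higher numbers stand for an effect only at larger amounts of compound and lower numbers for an effect already at smaller amounts), compound 1 `Cn1c(=N)sc2cc(OC(F)(F)F)ccc21` gives 5 mg/kg. Compound 2 `C=CCn1c(=N)sc2cc(OC(F)(F)F)ccc21`, with vinyl in place of hydrogen on a saturated chain carbon bound to an aromatic nitrogen, gives 7 mg/kg. Going by the values given here, that comparison is a 1.4-fold higher number from compound 1 to compound 2 (0.15 log units; within the scatter), so compound 2 sits level with the only other number available.

Compound 3 `COC(=O)Cn1c(=N)sc2cc(OC(F)(F)F)ccc21` changes the same place again: methoxycarbonyl in place of vinyl on a saturated chain carbon bound to an aromatic nitrogen. In words, this is methoxycarbonyl in place of vinyl on a saturated chain carbon bound to an aromatic nitrogen, or allyl giving way to (methoxycarbonyl)methyl.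

Among the compounds with values here, only one measured step touches this place, and that step, a 1.4-fold higher number from compound 1 to compound 2 (0.15 log units; within the scatter), shows little response to the first change made there. Within the data shown here, it is a thin guide, however, as no measured compound yet carries methoxycarbonyl, so a larger move in either direction cannot be ruled out. In this assay, the expected result is a 1.4-fold higher number from compound 2 to compound 3 (0.15 log units; within the scatter), which would be no real shift. Compound 3 is therefore estimated at 10 mg/kg, with an expected range from 3.5 mg/kg to 30 mg/kg.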

Compound 3, dose for half-maximal effect: > 10 mg/kg
Compound 3: no number, only a limit; the forecaster's own chance of this, stated with the estimate: 10%; the middle value sits exactly at the limit.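

Compound 3 gives a limit rather than a number: the limit of > 10 mg/kg in this assay, at which 1 of the 3 values shown sits. With methoxycarbonyl in place of vinyl on the saturated chain carbon bound to the aromatic nitrogen, the result in this assay is an at least 1.4-fold higher number from compound 2 to compound 3 (0.15 log units; that floor lies within the scatter), and with methoxycarbonyl in place of hydrogen at that carbon it is an at least 2.0-fold higher number from compound 1 to compound 3 (0.30 log units; that floor lies within the scatter). Both steps give only a floor, and neither floor lies beyond the scatter, so this position has not been shown to respond to methoxycarbonyl, yet the small response seen with vinyl cannot be assumed to hold for this group.

The compounds shown leave open how far the true dose of compound 3 lies past its limit, and so whether this change has a large effect or almost none. They also leave open whether a carboxylic acid, an amide or a longer chain at the same carbon would give a measurable dose in this assay, which would show whether the result belongs to methoxycarbonyl alone.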